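Capping the pyrazole nitrogen of compound 2 with a benzyl group

The source may hold more compounds than are shown below. What is called first, only, known or untested is meant among the compounds shown, and "the series" means these compounds.

Of the compounds shown here, two sharing one fused core have been tested so far. Compound 1 `COc1cc(Nc2nc(C(=N)Nc3ccccc3)cc3c(-c4ccccc4)n[nH]c23)cc(OC)c1OC` carries a 3,4,5-trimethoxyphenyl group on a nitrogen attached to the core, and in a functional assay on PC-3 cells (Homo sapiens) for cytotoxicity, read by MTT assay, with a stated time of 72 h (on this read-out higher numbers stand for weaker inhibition and lower numbers for stronger inhibition), compound 1 gives 5800 nM. Compound 2 `N=C(Nc1ccccc1)c1cc2c(-c3ccccc3)n[nH]c2c(NC2CCCCC2)n1` differs in one place, and in this assay compound 2 gives 1730 nM. For the measured compounds named here, the single measured step, a 3.4-fold lower number from compound 1 to compound 2 (0.53 log units; beyond the scatter), places compound 2 as the lower of the two numbers, that is, the stronger inhibitor in this pair.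

Compound 3 `COc1ccc(Cn2nc(-c3ccccc3)c3cc(C(=N)Nc4ccccc4)nc(NC4CCCCC4)c32)cc1` is the next compound and has not yet been measured. It differs from compound 2 in one place: 4-methoxybenzyl in place of hydrogen on an aromatic nitrogen. Going by the values given here, no measured step touches that position; the only step on record, from compound 1 to compound 2, concerns a different part of the molecule, so it gives no direct guide here. With nothing to point either way, the expectation for the step in this assay is one that stays within the scatter, a 1.4-fold higher number from compound 2 to compound 3 (0.16 log units; within the scatter). Compound 3 is therefore estimated at 2500 nM, in a range from 600 nM to 10000 nM.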

Compound 3, half-maximal inhibitory concentration: 1100 nM
Beside the measured number, compound 3's estimate is 2.3-fold (0.36 log units) above it; measured number inside the range.
By their numbers in this assay, from the lowest: compounds 3 and 2 (each within the scatter of the next); then compound 1.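

Placing 4-methoxybenzyl on the aromatic nitrogen, where compound 2 carries only hydrogen, gives a 1.6-fold lower number from compound 2 to compound 3 (0.20 log units; within the scatter) in this assay. For the compounds shown here, this is the first look at this position, and it shows that the hydrogen on this nitrogen can be replaced by a group of 9 heavy atoms, including a whole six-membered aromatic ring, with no change in the cell read-out that stands clear of the scatter. No measurement on hand explains this outcome or shows what the added group does in the cells.

The compounds shown leave open whether this result belongs to 4-methoxybenzyl in particular or would hold for other groups on the same nitrogen, such as a plain methyl, an unsubstituted benzyl, or a longer chain ending in an amine. They also leave open whether the same change would give a similar step on the 3,4,5-trimethoxyphenyl series of compound 1, which so far is known only with hydrogen on this nitrogen.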